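The compounds below may be only part of what the source reports. "The series", "measured", "known", "first", "only" and "open" are said of these compounds alone.

For the measured compounds named here, in an assay on isolated protein for inhibition of ubiquitin carboxyl-terminal hydrolase 7 (Homo sapiens), with stated times of 30 min and 2 h (on this read-out higher numbers stand for weaker inhibition and lower numbers for stronger inhibition), compound 1, `Cn1nc2c(=O)n(CC3(O)CCN(Cc4ccc(-c5ccco5)cc4Cl)CC3)cnc2c1-c1ccc(CNS(C)(=O)=O)cc1`, gives 65.3 nM, the lower of the two numbers known so far; compound 2, `Cn1nc2c(=O)n(CC3(O)CCN(Cc4ccc(-c5ccc(C(=O)O)o5)cc4Cl)CC3)cnc2c1-c1ccc(CN)cc1`, gives 753 nM. Compound 3, `CN(C)Cc1ccc(-c2c3ncn(CC4(O)CCN(Cc5ccc(-c6ccco6)cc5Cl)CC4)c(=O)c3nn2C)cc1`, has not yet been measured. It differs from compound 1 in one place: dimethylamino in place of methanesulfonamido on a saturated chain carbon bound to an aromatic carbon. Going by the values given here, no measured pair here shows this change alone, so nothing fixes the size of the step. The step of a 1.7-fold higher number from compound 1 to compound 3 (0.23 log units; within the scatter) is expected to stay within the usual scatter or to lean a little toward a higher number. Compound 3 is therefore estimated at 110 nM, with a range from 35 nM to 350 nM.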

Compound 3, half-maximal inhibitory concentration: 131 nM
For compound 3 the middle estimate is 1.2-fold (0.08 log units) below the measured one, within the range that was stated.
By their numbers in this assay, from the lowest: compounds 1 and 3 (each within the scatter of the next); then compound 2.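

In this assay, replacing the methanesulfonamido group on the chain carbon with dimethylamino gives a 2.0-fold higher number from compound 1 to compound 3 (0.30 log units; within the scatter), so this assay does not separate the two groups. This position therefore takes both a sulfonamide and a tertiary amine, which differ in size and in hydrogen-bond donors, without a step beyond the scatter. Nothing on hand explains this result. Still open, from the compounds shown here alone, is whether morpholino or acetamido on the same carbon would also stay within the scatter.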